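A few compounds are considered here, and "the series" means these few. Any claim that something is new, unique, unknown or untested is made for them only; others in the source may bear on it.

Measured compounds in a functional assay on MGC-803 cells (Homo sapiens) for cytotoxicity, read by MTT assay, with a stated time of 72 h; on this read-out higher numbers stand for weaker inhibition and lower numbers for stronger inhibition:
- compound 1 `CC(C)NC(=O)N1CCN(C(=S)SCc2cn(Cc3ccccc3F)nn2)CC1`, 1620 nM
- compound 2 `NC(=O)N1CCN(C(=S)SCc2cn(Cc3ccc(F)cc3)nn2)CC1`, 9330 nM
- compound 3 `CCNC(=O)N1CCN(C(=S)SCc2cn(Cc3ccc(F)cc3)nn2)CC1`, 2170 nM

Compound 3 stands below compound 2 beyond the scatter, while its number and that of compound 1 lie within the scatter of each other. Compound 4 `CC(C)NC(=O)N1CCN(C(=S)SCc2cn(Cc3ccc(F)cc3)nn2)CC1` differs from compound 3 by methyl in place of hydrogen on a saturated chain carbon bound to an amide-type nitrogen and a saturated chain carbon, i.e. ethyl to isopropyl on the carbamoyl nitrogen. For the measured compounds named here, one measured step bears on this region: a 4.3-fold lower number from compound 2 to compound 3 (0.63 log units; beyond the scatter). Compound 1 carries the same isopropylcarbamoyl group on a different fluorobenzyl and gives 1620 nM, close to compound 3. A step no larger than the scatter is therefore expected from compound 3 to compound 4, a 1.3-fold lower number from compound 3 to compound 4 (0.11 log units; within the scatter). Compound 4 is estimated at 1700 nM, range 800 nM to 3600 nM.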

Compound 4, half-maximal inhibitory concentration: 760 nM
Beside the measured number, compound 4's estimate is 2.2-fold (0.35 log units) above it, and the stated range ends above it.
By their numbers in this assay, from the lowest: compound 4; then compounds 1 and 3 (each within the scatter of the next); then compound 2.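

In this assay, the carbamoyl nitrogen still responds beyond ethyl: ethyl to isopropyl gives a 2.9-fold lower number from compound 3 to compound 4 (0.46 log units; beyond the scatter) and brings the full change from hydrogen to a 12-fold lower number from compound 2 to compound 4 (1.09 log units; beyond the scatter) in the 4-fluorobenzyl compounds. The fluorine position also counts, with 4-fluorophenyl in place of 2-fluorophenyl giving a 2.1-fold lower number from compound 1 to compound 4 (0.33 log units; beyond the scatter) on the isopropylcarbamoyl group. No available evidence accounts for either step.

Open, on these data alone, is whether the fall in the numbers continues with a longer chain such as n-butyl, a cyclopropyl group or a terminal amine on that nitrogen.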